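Sulfonylated glutamyl peptides against matrilysin: compound 4

The source may hold more compounds than are shown below. What is called first, only, known or untested is meant among the compounds shown, and "the series" means these compounds.

Measured in an assay on isolated protein for inhibition of Matrilysin (Homo sapiens), read by fluorescence, with a stated time of 15 min; on this read-out higher numbers stand for weaker inhibition and lower numbers for stronger inhibition:
compound 1 `CC(C)C[C@H](NC(=O)[C@H](C)NC(=O)CC[C@H](NS(=O)(=O)c1ccc(Cl)c(C(F)(F)F)c1)C(=O)O)C(=O)N[C@@H](C)C(N)=O` gives 1700 nM
compound 2 `CC(C)C[C@H](NC(=O)CNC(=O)CC[C@H](NS(=O)(=O)c1ccc(Cl)c(C(F)(F)F)c1)C(=O)O)C(=O)N[C@H](C(=O)N[C@@H](C)C(N)=O)C(C)C` gives 16 nM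
compound 3 `CC(C)C[C@H](NC(=O)CNC(=O)CC[C@H](NS(=O)(=O)c1ccc(Cl)c(C(F)(F)F)c1)C(=O)O)C(=O)N[C@H](C(=O)N1CCC[C@H]1CC(N)=O)C(C)C` gives 10 nM

Compound 1 stands at the highest number of the three, that is the weakest inhibition in this assay; compound 2 and compound 3 both sit far lower, beyond the scatter. Those two share a backbone that differs from compound 1 in more than one place, so their gap to compound 1 cannot be traced to a single change.

Compound 4 `CSCC[C@H](NC(=O)[C@H](CC(C)C)NC(=O)[C@H](C)NC(=O)CC[C@H](NS(=O)(=O)c1ccc(Cl)c(C(F)(F)F)c1)C(=O)O)C(N)=O` differs from compound 1 by (methylsulfanyl)methyl in place of hydrogen on a saturated chain carbon, two bonds along the chain from an amide-type nitrogen and a carbonyl carbon. For the measured compounds named here, the only single-point step in this assay, a 1.6-fold lower number from compound 2 to compound 3 (0.20 log units; within the scatter), concerns a different position and lies within the scatter; it does not bear on the change from compound 1 to compound 4. Going by the values given here, no measured pair speaks to the entry of (methylsulfanyl)methyl at this position.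

With nothing in the data pointing either way, compound 4 is expected to stay close to compound 1, the step of a 1.4-fold lower number from compound 1 to compound 4 (0.15 log units; within the scatter) being estimated as none beyond the scatter. For compound 4 the estimate in this assay is 1200 nM, with a range from 300 nM to 5000 nM that leaves room for a modest shift in either direction.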

Compound 4, half-maximal inhibitory concentration: 440 nM
Compound 4: the middle estimate sits 2.7-fold (0.44 log units) above what was measured; the measured number falls inside the stated range.
By their numbers in this assay, from the lowest: compounds 3 and 2 (each within the scatter of the next); then compound 4; then compound 1.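

In this assay, (methylsulfanyl)methyl in place of hydrogen on a saturated chain carbon, two bonds along the chain from an amide-type nitrogen and a carbonyl carbon, gives a 3.9-fold lower number from compound 1 to compound 4 (0.59 log units; beyond the scatter). For the compounds shown here, this is a modest step, but it is the first single-point change to reach beyond the scatter, so this position responds to substitution, with methyl to 2-(methylsulfanyl)ethyl moving the number towards stronger inhibition. No measurement at hand accounts for the step.

The compounds shown leave open whether the step belongs to the sulfur of the 2-(methylsulfanyl)ethyl group or to the chain length alone; a plain butyl chain at this position would separate the two, while an amine or a carboxylic acid at the chain end would test how far the position tolerates a different end group. Also open, from the compounds shown here alone, is whether the same change gives a step of similar size on the backbone shared by compound 2 and compound 3.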